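This account rests on a few compounds, and the source may have more. Where it says the series, first, only, none or still open, it means among the compounds named here.

In an ADME assay on the whole organism (strain CD-1) for pharmacokinetics, with Mus musculus as the target, at a dose of 3 mg/kg by the intravenous route (on this read-out higher numbers stand for higher exposure at the dose given and lower numbers for lower exposure), the measured compounds read:

Compound 1 `CN(Cc1ccccc1OCCCCC(C)(C)C(=O)O)C(=O)c1ccc(-c2ccco2)cc1` gives 48400 ng.h/mL
Compound 2 `CN(Cc1ccccc1OCCC[C@@H]1C[C@@H]1C(=O)O)C(=O)c1ccc(-c2ccco2)cc1` gives 30100 ng.h/mL
Compound 3 `CN(Cc1ccccc1OCCC[C@@H]1C[C@H]1C(=O)O)C(=O)c1ccc(-c2ccco2)cc1` gives 40500 ng.h/mL

Compound 3 is not separated from the other two (a 1.2-fold lower number from compound 1 to compound 3 (0.08 log units; within the scatter) and a 1.3-fold higher number from compound 2 to compound 3 (0.13 log units; within the scatter)). Compound 4 (`C/C(=C\CCCOc1ccccc1CN(C)C(=O)c1ccc(-c2ccco2)cc1)C(=O)O`) differs from compound 3 by one change (2-carboxyprop-1-en-1-yl in place of 2-carboxycyclopropyl on a saturated chain carbon, three bonds along the chain from an oxygen on an aromatic ring), with 2-carboxyprop-1-en-1-yl in place of 2-carboxycyclopropyl on a saturated chain carbon, three bonds along the chain from an oxygen on an aromatic ring. The closest evidence is the earlier exchange of the chain end (a 1.6-fold lower number from compound 1 to compound 2 (0.21 log units; within the scatter) and a 1.2-fold lower number from compound 1 to compound 3 (0.08 log units; within the scatter)), and both steps stay within the scatter. The pair differing only in configuration (the fact that compounds 2 and 3 differ only in the configuration as drawn) shows no step beyond it either (a 1.3-fold higher number from compound 2 to compound 3 (0.13 log units; within the scatter)). Among the measured compounds shown here, no measured compound carries 2-carboxyprop-1-en-1-yl, so this support is indirect. No step beyond the scatter is therefore expected in this assay for this exchange, and no direction can be favoured. The expected step is small (a 1.1-fold lower number from compound 3 to compound 4 (0.03 log units; within the scatter)). For compound 4 the estimated value is 38000 ng.h/mL in a range expected to run from 17000 ng.h/mL to 75000 ng.h/mL overall.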

Compound 4, area under the concentration-time curve: 1300 ng.h/mL
Compound 4: middle estimate off by 29-fold (1.47 log units), on the high side; measured number outside the range, below it.
By their numbers in this assay, from the lowest: compound 4; then compounds 2, 3 and 1 (each within the scatter of the next).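

In this assay, this position, on a saturated chain carbon, three bonds along the chain from an oxygen on an aromatic ring, proves sensitive to the chain end: moving to 2-carboxyprop-1-en-1-yl gives a 31-fold lower number from compound 3 to compound 4 (1.49 log units; beyond the scatter), a 23-fold lower number from compound 2 to compound 4 (1.36 log units; beyond the scatter) and a 37-fold lower number from compound 1 to compound 4 (1.57 log units; beyond the scatter), whereas the exchanges among the earlier ends stayed within the scatter. Compound 4 has the same atoms as compound 3, so the atoms of the chain end alone do not set the exposure. The step is large from either drawn form of 2-carboxycyclopropyl, so it does not depend on that configuration: the fact that compounds 2 and 3 differ only in the configuration as drawn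

Only compound 4 carries this end, so the result rests on a single structure. As far as these compounds go, it remains open whether a 2-carboxyethenyl end without the methyl, the opposite geometry about the double bond, or a tetrazole in place of the carboxylic acid would give a number as low as that of compound 4.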